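A Fluoro Group Added to Compound 2

The source may report more compounds than this note shows. Statements on the series, on what has been measured and on what is new or still open speak of the compounds shown alone.

In a functional assay on MCF7 cells (Homo sapiens) for cytotoxicity, read by MTT assay, with a stated time of 72 h (a lower number here means a stronger inhibitor, a higher number a weaker inhibitor), compound 3 `CNC(=O)c1cc(Oc2ccc(NC(=O)c3cc(-c4ccccc4)ncn3)cc2)ccn1` gives 18200 nM and compound 2 `CNC(=O)c1cc(Oc2ccc(NC(=O)c3cc(-c4ccc(C)cc4)ncn3)cc2)ccn1` gives 34600 nM, the higher of the two numbers, although the step of a 1.9-fold lower number from compound 2 to compound 3 (0.28 log units; within the scatter) sits within the scatter. Compound 1 `CNC(=O)c1cc(Oc2ccc(NC(=O)c3cc(-c4ccc(Cl)cc4)ncn3)cc2)ccn1` reaches only the limit > 100000 nM in this assay. That limit of > 100000 nM in this assay, at which 1 of the 3 values shown sits, is why the steps of an at least 2.8-fold lower number from compound 1 to compound 2 (0.46 log units; beyond the scatter) and an at least 5.4-fold lower number from compound 1 to compound 3 (0.73 log units; beyond the scatter) can be stated only as at least modest. Compound 4 `CNC(=O)c1cc(Oc2ccc(NC(=O)c3cc(-c4ccc(C)cc4)ncn3)cc2F)ccn1` differs from compound 2 by fluoro in place of hydrogen on an aromatic carbon. Within the data shown here, none of the measured steps touches that carbon; all three swap chloro, methyl or hydrogen on another ring, so no step beyond the scatter is expected. Compound 4 is therefore estimated at 25000 nM, between 8000 nM and 80000 nM, the expected step of a 1.4-fold lower number from compound 2 to compound 4 (0.14 log units; within the scatter) being small.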

Compound 4, half-maximal inhibitory concentration: 19200 nM
Estimate against measurement, compound 4: 1.3-fold (0.11 log units) above; low and high end bracket the measured number.
By their numbers in this assay, from the lowest: compounds 3, 4 and 2 (each within the scatter of the next). At a limit, above all of these: compound 1.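

The earlier compounds changed only a group on another ring, so this is the first change shown on the six-membered aromatic ring of carbon only, ortho to the (2-(methylcarbamoyl)pyridin-4-yl)oxy group. In this assay, fluoro in place of hydrogen there gives a 1.8-fold lower number from compound 2 to compound 4 (0.26 log units; within the scatter), so this carbon accepts fluoro without a step that can be told from the scatter. Nothing shown gives a reason for the size of this step.

On these data alone, whether methoxy or an amine at this carbon would move the number beyond the scatter remains open. So does whether fluoro here would do the same in compound 3.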